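Fluoro in place of hydrogen on a thioether-linked phenyl

The source may hold more compounds than are shown below. What is called first, only, known or untested is meant among the compounds shown, and "the series" means these compounds.

Compound 1 `Cn1c(-c2ccccc2)nc2c(Sc3ccc(F)cc3)ncnc21`: 9%
Compound 2 `Cn1c(-c2ccc([S+](C)[O-])cc2)nc2c(Sc3ccc(F)cc3)ncnc21`: 0%
Compound 3 `Cn1c(-c2ccc(S(C)(=O)=O)cc2)nc2c(Sc3ccccc3)ncnc21`: 5%

In an assay on isolated protein for inhibition of Rho-associated protein kinase 1 (Homo sapiens), tested at 30 uM (on this read-out higher numbers stand for more inhibition at the one concentration tested (going by the name of the read-out) and lower numbers for less inhibition), compound 1 gives 9%. Compound 2, which carries a methylsulfinyl group in place of a hydrogen on the phenyl attached to the shared core, gives 0%; the measured step is a number 9 percentage points lower from compound 1 to compound 2 (within the scatter). Compound 3 gives 5% in this assay, which places it between the other two, but its gap to compound 1 and its gap to compound 2 both lie within the scatter, so the three measured compounds cannot be told apart on these numbers.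

Compound 4 `Cn1c(-c2ccc(S(C)(=O)=O)cc2)nc2c(Sc3ccc(F)cc3)ncnc21` has not yet been measured. It differs from compound 3 by fluoro in place of hydrogen on an aromatic carbon on the phenylsulfanyl side of the core. Going by the values given here, none of the measured steps concerns this change: the only single-point step, from compound 1 to compound 2, alters the other phenyl ring, and compound 1 and compound 3 differ in two places at once. The data therefore give no basis for a shift beyond the scatter. On that account the step to compound 4 is expected to be no change at the digits printed from compound 3 to compound 4 (within the scatter), and in this assay compound 4 is estimated at 5%, within a range from -5% to 15%.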

Compound 4, a percentage reported as inhibition, at one concentration (the size of the read-out at that concentration, not a potency): 0%
For compound 4 the middle estimate is 5 percentage points above the measured one; low and high end bracket the measured number.
By their numbers in this assay, from the lowest: compounds 2, 4, 3 and 1 (each within the scatter of the next).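

In this assay, going by these compounds alone, the fluoro group gives the first single-point reading on the phenylsulfanyl side of the shared core, a number 5 percentage points lower from compound 3 to compound 4 (within the scatter), so phenylsulfanyl to (4-fluorophenyl)sulfanyl cannot be told from no effect on this read-out. Compound 4 also supplies two readings for the other phenyl ring: methylsulfonyl in place of hydrogen gives a number 9 percentage points lower from compound 1 to compound 4 (within the scatter), and the methylsulfonyl group in place of the methylsulfinyl group gives no change at the digits printed from compound 2 to compound 4 (within the scatter), so neither replacement there separates from no effect either. Nothing at hand bears on why these compounds read as they do.

What stays open is whether any group on either phenyl ring can carry the inhibition beyond the scatter, since an amine or a carboxylic acid in place of the fluoro or the methylsulfonyl group is not among the compounds shown. Also open, going by these compounds, is whether a longer chain in place of the methyl group on the shared core would read any differently in this assay.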